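The source may hold more compounds than are shown below. What is called first, only, known or untested is meant among the compounds shown, and "the series" means these compounds.

Measured so far:
compound 1 `CN1CCN(c2cccc3nc(CN(C)[C@H]4CCCc5cccnc54)cn23)CC1`, 4500 nM
compound 2 `CN1CCC(N(C)c2cccc3nc(CN(C)[C@H]4CCCc5cccnc54)cn23)C1`, 10800 nM

Among the compounds with values here, in an ADME assay on HOS cells (Homo sapiens) for cytotoxicity (a higher number here means that more compound is tolerated, a lower number that less compound is tolerated), compound 2 holds the higher of the two numbers, and the only measured step is a 2.4-fold higher number from compound 1 to compound 2 (0.38 log units; beyond the scatter). Compound 3 `CNCCN(C)c1cccc2nc(CN(C)[C@H]3CCCc4cccnc43)cn12` is not yet measured; it differs from compound 2 in one place: 2-(methylamino)ethyl in place of 1-methylpyrrolidin-3-yl on a nitrogen on an aromatic ring. Within the data shown here, no measured step covers this kind of exchange: the one known step swaps a different ring for another, not a ring for an open chain. With nothing directly comparable, the expectation is a step of about a 1.1-fold lower number from compound 2 to compound 3 (0.03 log units; within the scatter), not clearly beyond the scatter in either direction. Compound 3 is therefore estimated at 10000 nM, with a range from 4000 nM to 25000 nM.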

Compound 3, half-maximal cytotoxic concentration: 2200 nM
The estimate for compound 3 lay 4.5-fold (0.66 log units) above the measured number, outside the stated range (below it).
By their numbers in this assay, from the lowest: compound 3; then compound 1; then compound 2.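

In this assay, the open chain 2-(methylamino)ethyl on this nitrogen brings a 4.9-fold lower number from compound 2 to compound 3 (0.69 log units; beyond the scatter) in place of the ring 1-methylpyrrolidin-3-yl, so this position does respond to the exchange of a ring for a chain. Set against the 4-methylpiperazin-1-yl of compound 1, the chain gives a 2.0-fold lower number from compound 1 to compound 3 (0.31 log units; beyond the scatter) and so leaves compound 3 the least tolerated of the three. Nothing available explains this result. On these data alone, whether the loss of the ring or the added hydrogen-bond donor matters more stays open, and a 2-(dimethylamino)ethyl chain at this position would help to separate the two.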